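A few compounds are considered here, and "the series" means these few. Any claim that something is new, unique, unknown or untested is made for them only; others in the source may bear on it.

Measured so far:
compound 1 `CC(=O)NCCCc1ccc2ncn(-c3ccnc(N)n3)c2c1` — in an assay on Sf9 cells for inhibition of mitogen-activated protein kinase kinase kinase 14 variant S549D (Homo sapiens), with a stated time of 30 min, in the presence of a further agent that is not named here (on this read-out lower numbers stand for stronger inhibition and higher numbers for weaker inhibition), compound 1 gives > 100000 nM, which is a limit of the assay and not a number.
compound 2 `C#Cc1cc(C#Cc2ccc3ncn(-c4ccnc(N)n4)c3c2)ccn1` — in this assay compound 2 gives 31600 nM.

Compound 2 therefore stands as the only one of the two with an actual number in this assay. Compound 1 sits at the limit (the limit of > 100000 nM in this assay, at which 1 of the 2 values shown sits), so the pair can be read only as far as saying that compound 1 returns no number while compound 2 does.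

The next compound, compound 3 `C#Cc1cncc(C#Cc2ccc3ncn(-c4ccnc(N)n4)c3c2)n1`, is not yet measured. It differs from compound 2 by a group of 8 heavy atoms (6 carbon, 2 nitrogen; one six-membered aromatic ring with 2 hetero atoms) in place of a group of 8 heavy atoms (7 carbon, 1 nitrogen; one six-membered aromatic ring with 1 hetero atom), on a triple-bonded carbon. Going by the values given here, no step between measured compounds that differ in one place is available, so nothing measured sets the size of this change. The writer expects the step from compound 2 to compound 3 in this assay to stay within the scatter or to lean slightly towards weaker inhibition, as a 1.3-fold higher number from compound 2 to compound 3 (0.10 log units; within the scatter). For compound 3 in this assay the estimate is 40000 nM, expected to fall between 12000 nM and 130000 nM.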

Compound 3, half-maximal inhibitory concentration: 6310 nM
Compound 3: the middle estimate sits 6.3-fold (0.80 log units) above what was measured; measured number below the stated range.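

Going by these compounds alone, the first step that can be read in this assay is a 5.0-fold lower number from compound 2 to compound 3 (0.70 log units; beyond the scatter), and it shows that the group on the triple-bonded carbon affects this read-out: the exchange keeps 8 heavy atoms and 1 triple bond outside aromatic rings, yet the number moves beyond the scatter. In this single pair, stronger inhibition goes with one six-membered aromatic ring with 2 hetero atoms and 2 hydrogen-bond acceptors in the entering group, where the leaving group had one six-membered aromatic ring with 1 hetero atom and 1 hydrogen-bond acceptor. No measurement shown here bears on why the number moves with this exchange.

With only one such exchange shown, it remains open whether the step follows the number of hetero atoms in the ring or the particular ring that enters in compound 3. Going by these compounds, it is also open how this read-out would respond if the group on the triple-bonded carbon carried an amine or a carboxylic acid, or if a saturated carbon chain took the place of the ring.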